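Benzenesulfonamide series: moving the methyl on the phenoxy group

The compounds below may be only part of what the source reports. "The series", "measured", "known", "first", "only" and "open" are said of these compounds alone.

Among the measured compounds shown here, compound 2 `Cc1cccc(Oc2cc(F)cc(N3Cc4ccccc4S3(=O)=O)c2)c1` is the higher of the two numbers measured so far in a functional assay on Flp-In T-REx293 cells for antagonist activity at Free fatty acid receptor 1 (Homo sapiens), read by calcium flux; a higher number here means a larger maximal response, a lower number a smaller maximal response; compound 2 gives 51%. For the measured compounds named here, its only comparator is compound 1 `O=S1(=O)c2ccccc2CN1c1cc(F)cc(OCc2ccccc2)c1`, which in this assay gives 36%; the step of a number 15 percentage points higher from compound 1 to compound 2 (beyond the scatter) is the one measured change at this position, obtained by putting 3-methylphenyl in place of benzyl on an oxygen on an aromatic ring.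

Compound 3 `Cc1ccc(Oc2cc(F)cc(N3Cc4ccccc4S3(=O)=O)c2)cc1` keeps every atom of compound 2 and differs only in the arrangement of the methyl on the ring attached to the oxygen: 4-methylphenyl in place of 3-methylphenyl on an oxygen on an aromatic ring. Going by the values given here, the single measured step exchanged the whole group on the oxygen and was modest in size; it gives no direct read on shifting a methyl within an otherwise unchanged ring, and no other pair speaks to such a shift. With nothing pointing either way, the expectation for compound 3 in this assay is a step of a number 1 percentage points lower from compound 2 to compound 3 (within the scatter) that stays within the scatter. Compound 3 is therefore estimated at 50%, with a range from 35% to 65%.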

Compound 3, largest response reached (reported as Imax), in percent of the reference or control that the assay uses: 52%
Compound 3: the middle estimate sits 2 percentage points below what was measured; measured number inside the range.
By their numbers in this assay, from the lowest: compound 1; then compounds 2 and 3 (each within the scatter of the next).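

In this assay, moving the methyl reads as a number 1 percentage points higher from compound 2 to compound 3 (within the scatter), so 3-methylphenyl and 4-methylphenyl on this oxygen cannot be told apart by maximal response, which is something the exchange of the whole group could not show. Measured against the benzyl group, 4-methylphenyl gives a number 16 percentage points higher from compound 1 to compound 3 (beyond the scatter) and 3-methylphenyl gives a number 15 percentage points higher from compound 1 to compound 2 (beyond the scatter), so the separation from compound 1 holds for both methyl arrangements and does not depend on which of the two is present. Nothing available bears on why the number stays put when the methyl moves.

As far as these compounds go, whether the methyl is needed at all remains open, as an unsubstituted phenyl on the oxygen would be the direct comparison, and it is equally unclear whether a longer chain such as ethyl or propyl would read like methyl here. From the compounds shown here alone, what a methoxy group, an amine or a carboxylic acid in place of the methyl would do to the maximal response is also open, as is the part played by the fluorine on the shared core.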